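Swapping the ring on a dithiocarbamate chromone

The source may hold more compounds than are shown below. What is called first, only, known or untested is meant among the compounds shown, and "the series" means these compounds.

Three compounds built around a chromone core carrying a dithiocarbamate group have been tested in a functional assay on LM7 cells (Homo sapiens) for antiproliferative activity, read by MTT assay, with a stated time of 72 h; a lower number here means a stronger inhibitor, a higher number a weaker inhibitor. Compound 1 `O=c1cc(CSC(=S)N2CCOCC2)oc2cc(Cl)ccc12` reaches only the limit of the assay, giving > 25000 nM. Compound 3 `CN(C(=S)SCc1coc2ccccc2c1=O)c1ccccc1` likewise sits at the limit of the assay, with > 25000 nM. Among the compounds with values here, compound 2 `CCOC(=O)c1cc(=O)c2cc(CSC(=S)N3CCCC3)ccc2o1` is the single compound with a measured number, giving 18000 nM. Compound 2 therefore stands as the only point on the scale among the three. Compound 1 and compound 3 both sit at the limit of the assay (the limit of > 25000 nM in this assay, at which 2 of the 3 values shown sit).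

Compound 4 `CCOC(=O)c1cc(=O)c2cc(CSC(=S)N3CCOCC3)ccc2o1` has not been measured. It differs from compound 2 in one place: morpholin-4-yl in place of pyrrolidin-1-yl on a thiocarbonyl carbon. Within the data shown here, no comparable step between measured compounds exists to guide the size of this change. Given that compound 2 already gives 18000 nM, a weak value, the expected step of a 1.4-fold higher number from compound 2 to compound 4 (0.14 log units; within the scatter) is small, within the scatter or modestly toward weaker inhibition. Compound 4 is therefore estimated at 25000 nM, within a range from 12000 nM to 60000 nM, with a fair chance that only a limit is reported.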

Compound 4, half-maximal inhibitory concentration: > 25000 nM
Compound 4 was reported as a limit; the forecaster's own chance of this, stated with the estimate: 55%; the middle value lies on the limit itself.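

In this assay compound 4 gives > 25000 nM, which is a limit of the assay and not a number. Morpholin-4-yl in place of pyrrolidin-1-yl on a thiocarbonyl carbon gives an at least 1.3-fold higher number from compound 2 to compound 4 (0.14 log units; that floor lies within the scatter), so this first comparison at this place offers no sign of a stronger inhibitor, while the true size of the step stays unknown. Compound 2 remains the only compound with a measured number, and the others all crowd at the edge of the scale: the limit of > 25000 nM in this assay, at which 3 of the 4 values shown sit.

The compounds shown leave open whether piperidin-1-yl or an open-chain diethylamino group on the thiocarbonyl carbon would give a readable number. Also open, from the compounds shown here alone, is whether a carboxylic acid in place of the ethyl ester of compound 2 would change the picture.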